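Fluoro in place of hydrogen on two cores

This account rests on a few compounds, and the source may have more. Where it says the series, first, only, none or still open, it means among the compounds named here.

Compound 1 `CCOc1ccc2nc(Nc3nc4ccc(F)cc4s3)sc2c1` and compound 2 `CCOc1ccc2nc(Nc3nc4ccccc4s3)sc2c1` share one core; compound 3 `Cc1ccc2nc(NC(=S)Nc3ccccc3)sc2c1` carries another, and the difference between the two cores is not broken down here. In a functional assay on B16-F10 cells (Mus musculus) for cytotoxicity, read by MTT assay, with a stated time of 48 h (on this read-out higher numbers stand for weaker inhibition and lower numbers for stronger inhibition), compound 1 gives 33200 nM. Compound 2 reaches only the assay limit in this assay, > 50000 nM. Compound 3 likewise gives only a limit in this assay, > 50000 nM. Note (the limit of > 50000 nM in this assay, at which 2 of the 3 values shown sit). The change fluoro in place of hydrogen on an aromatic carbon gave an at least 1.5-fold lower number from compound 2 to compound 1 (0.17 log units; that floor lies within the scatter). Compound 4 `Cc1ccc2nc(NC(=S)Nc3ccc(F)cc3)sc2c1` arises from compound 3 by the same kind of change, (fluoro in place of hydrogen on an aromatic carbon); here the site is on a ring of carbon only, para to a large group, whereas in compound 1 it is part of a fused or bridged system of two rings, meta to a fused ring and para to a fused ring. The expected step is a number no higher from compound 3 to compound 4 (the limit leaves the size open), resting on the small measured step of an at least 1.5-fold lower number from compound 2 to compound 1 (0.17 log units; that floor lies within the scatter) taken from a limit. Compound 4 is therefore expected near 50000 nM, between 20000 nM and 150000 nM, most likely reported again only as a limit.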

Compound 4, half-maximal inhibitory concentration: > 50000 nM
Compound 4: a limit, no number (the forecaster's own chance of this, stated with the estimate: 65%); the middle value sits exactly at the limit.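

In this assay, going by these compounds alone, compound 3 and compound 4 both stand only as limits, so no step between them can be read. Going by these compounds, whether phenyl to 4-fluorophenyl changes the number on this core at all remains open.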